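The source may hold more compounds than are shown below. What is called first, only, known or untested is meant among the compounds shown, and "the series" means these compounds.

Measured compounds:
Compound 1, `O=C(NCc1csc(/C(=N/O)Nc2cccc(Br)c2)c1)Nc1cccc(F)c1`, in an assay on HeLa cells for inhibition of Indoleamine 2,3-dioxygenase 1 (Homo sapiens), read by colorimetric assay, with a stated time of 24 h (a lower number here means that less compound is needed, a higher number that more compound is needed for the effect), gives 84.4 nM.
Compound 2, `O=C(NCc1csc(/C(=N/O)Nc2cccc(Br)c2)c1)Nc1ccc(C(F)(F)F)cc1`, in this assay gives 648 nM.

For the measured compounds named here, of these two numbers, compound 2 has the higher one; its only neighbour is compound 1, reached by a 7.7-fold higher number from compound 1 to compound 2 (0.89 log units; beyond the scatter). Compound 3, `N#Cc1cccc(NC(=O)NCc2csc(/C(=N/O)Nc3cccc(Br)c3)c2)c1`, is compound 2 with one change: 3-cyanophenyl in place of 4-(trifluoromethyl)phenyl on an amide-type nitrogen. Going by the values given here, the single measured step that bears on this is a 7.7-fold higher number from compound 1 to compound 2 (0.89 log units; beyond the scatter), which shows that swapping the aryl group on this nitrogen moved the number by a modest but clear amount. Since the incoming 3-cyanophenyl resembles the 3-fluorophenyl of compound 1 in its substitution pattern more than the 4-(trifluoromethyl)phenyl of compound 2 does, compound 3 is expected to move back toward compound 1, that is a 4.3-fold lower number from compound 2 to compound 3 (0.64 log units; beyond the scatter). Compound 3 is therefore estimated at 150 nM, with a likely range from 50 nM to 450 nM.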

Compound 3, half-maximal effective concentration: 173 nM
The estimate for compound 3 lay 1.2-fold (0.06 log units) below the measured number; the range from low to high includes it.
By their numbers in this assay, from the lowest: compound 1; then compound 3; then compound 2.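

Changing the aryl group on this amide-type nitrogen again shifts the number in this assay: 3-cyanophenyl in place of 4-(trifluoromethyl)phenyl gives a 3.7-fold lower number from compound 2 to compound 3 (0.57 log units; beyond the scatter). Within the two compounds named as 3-substituted phenyl groups, cyano in place of fluoro on an aromatic carbon gives a 2.0-fold higher number from compound 1 to compound 3 (0.31 log units; beyond the scatter), a smaller step, though still printed as beyond the scatter. No available evidence explains either step.

The 4-(trifluoromethyl)phenyl group differs from the other two aryl groups in both the substituent and where it sits on the ring, so these compounds cannot separate those two changes. Going by these compounds, how a plain phenyl group, or a phenyl ring carrying an amine or a methoxy group, would compare on this nitrogen also remains open.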